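Quinolinyl to pyridinyl at the aryl position of the core

The source may hold more compounds than are shown below. What is called first, only, known or untested is meant among the compounds shown, and "the series" means these compounds.

Measured compounds:
compound 1 `C=CC(=O)Nc1cccc(Oc2ncnc3ccc(-c4ccc(Cl)nc4)cc23)c1`: in a functional assay on Raji cells (Homo sapiens) for inhibition, read by MTT assay, with a stated time of 48 h (a lower number here means a stronger inhibitor, a higher number a weaker inhibitor), compound 1 gives "not determined" (no result reported)
compound 2 `C=CC(=O)Nc1cccc(Oc2ncnc3ccc(-c4cnc5ccccc5c4)cc23)c1`: in this assay compound 2 gives 8600 nM

For the measured compounds named here, compound 2 holds the only number recorded in this assay; compound 1 contributes no value, so no step between measured compounds can be stated. Compound 3 `C=CC(=O)Nc1cccc(Oc2ncnc3ccc(-c4cccnc4)cc23)c1` differs from compound 2 by pyridin-3-yl in place of quinolin-3-yl on an aromatic carbon. Going by the values given here, with no measured step to lean on, a modest shift is expected, if any, and most likely towards a weaker result or within the scatter. Compound 3 is estimated at 12000 nM in this assay, within 4000 nM to 40000 nM, meaning an expected step of a 1.4-fold higher number from compound 2 to compound 3 (0.14 log units; within the scatter).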

Compound 3, half-maximal inhibitory concentration: 14800 nM
The estimate for compound 3 lay 1.2-fold (0.09 log units) below the measured number, within the range that was stated.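

In this assay, for the compounds shown here, pyridin-3-yl in place of quinolin-3-yl gives a 1.7-fold higher number from compound 2 to compound 3 (0.24 log units; within the scatter), the first step that can be read at this position. The six-membered aromatic ring of carbon only in quinolin-3-yl can therefore be lost here with a step that stays within the scatter, so the two groups cannot be told apart in this assay. No supporting data bear on this result. On these data alone, it remains open whether an aminomethyl group or a carboxylic acid on the pyridin-3-yl ring would move the number beyond the scatter.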